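Methyl in place of fluoro on the phenyl of compound 3

The compounds below may be only part of what the source reports. "The series", "measured", "known", "first", "only" and "open" are said of these compounds alone.

The series shares one amide core carrying a tetrazole with an aryl substituent. Compound 1 `Cc1cc(NC(=O)Cn2nnc(-c3ccccc3)n2)n(C(C)C)n1` gives 556 nM in an assay on HEK293 cells for activation of Kir3.1/Kir3.2 (Homo sapiens), read by thallium flux; on this read-out lower numbers stand for an effect already at smaller amounts and higher numbers for an effect only at larger amounts of compound. For the measured compounds named here, compound 2 `Cc1cc(NC(=O)Cn2nnc(-c3cccnc3)n2)n(C2CCCCC2)n1` gives 1930 nM in this assay, and compound 3 `Cc1cc(NC(=O)Cn2nnc(-c3ccc(F)cc3)n2)n(C2CCCCC2)n1` gives 180 nM in this assay, the lowest of the three numbers; the only single-point step available is an 11-fold lower number from compound 2 to compound 3 (1.03 log units; beyond the scatter), while the gap to compound 1 involves two changes at once and is read from the two values alone.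

Compound 4 `Cc1ccc(-c2nnn(CC(=O)Nc3cc(C)nn3C3CCCCC3)n2)cc1` differs from compound 3 by methyl in place of fluoro on an aromatic carbon, on an aromatic carbon of a six-membered aromatic ring of carbon only, para to a large group; cut one bond further out, the change reads 4-fluorophenyl to 4-methylphenyl. Going by the values given here, no measured step exchanges these two groups. Among the compounds with values here, the one step that touches this ring, from pyridin-3-yl to 4-fluorophenyl, was large, but a fluoro-to-methyl exchange on a carbon-only ring is a different kind of change. The expectation for compound 4 is therefore a step of a 1.4-fold higher number from compound 3 to compound 4 (0.14 log units; within the scatter) in this assay, within the scatter and with no clear direction. Compound 4 is estimated at 250 nM, with a range from 90 nM to 700 nM.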

Compound 4, half-maximal effective concentration: 111 nM
Compound 4: middle estimate off by 2.3-fold (0.35 log units), on the high side, and the stated range covers the measured number.
By their numbers in this assay, from the lowest: compounds 4 and 3 (each within the scatter of the next); then compound 1; then compound 2.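

In this assay the exchange of fluoro for methyl on this aromatic carbon gives a 1.6-fold lower number from compound 3 to compound 4 (0.21 log units; within the scatter) and so does not separate the two groups at this position. The replacement of pyridin-3-yl by 4-methylphenyl gives a 17-fold lower number from compound 2 to compound 4 (1.24 log units; beyond the scatter) and stands alongside an 11-fold lower number from compound 2 to compound 3 (1.03 log units; beyond the scatter) as a second large step, so the large gap from compound 2 is no longer tied to 4-fluorophenyl alone. Nothing at hand explains these numbers.

Open, going by these compounds, is how an amine, a carboxylic acid or a longer chain in place of methyl would read on this aromatic carbon. Also open, on these data alone, is whether the exchange of fluoro for methyl reads the same with the group that compound 1 carries in place of the cyclohexyl of compound 3.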